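This account rests on a few compounds, and the source may have more. Where it says the series, first, only, none or still open, it means among the compounds named here.

Of the compounds shown here, three that share one core have so far been tested in a functional assay on A549 cells (Homo sapiens) for inhibition, read by MTT assay, with a stated time of 24 h; a higher number here means a weaker inhibitor, a lower number a stronger inhibitor. Compound 1 `CCOC(=O)C1=Cc2ccccc2OC1(OCc1cn(CC(=O)Nc2cccc(Cl)c2)nn1)C(F)(F)F`, which carries ethyl on an oxygen next to a carbonyl group and a triazole-linked anilide, gives 12800 nM there. For compound 2 `O=C(O)C1=Cc2ccccc2OC1(OCc1cc(-c2ccc([N+](=O)[O-])cc2)no1)C(F)(F)F`, the free acid bearing a 4-nitrophenyl, this assay reports only a limit, > 150000 nM, and no number. Compound 3 `CCOC(=O)C1=Cc2ccccc2OC1(OCc1cc(-c2ccc([N+](=O)[O-])cc2)no1)C(F)(F)F` likewise stands at a limit in this assay, > 150000 nM. Both of these values sit at the limit of > 150000 nM in this assay, at which 2 of the 3 values shown sit, so the step from compound 2 to compound 3, a step that the two limits leave unreadable from compound 2 to compound 3, which amounts to ethyl in place of hydrogen on an oxygen next to a carbonyl group, cannot be read in size or direction. Among the measured compounds shown here, compound 2 therefore stands only at a limit in this assay, with no measured step leading from it to a number.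

Compound 4 `O=C(O)C1=Cc2ccccc2OC1(OCc1cc(-c2ccc(F)cc2)no1)C(F)(F)F` differs from compound 2 by fluoro in place of nitro on an aromatic carbon. No measured step bears on this change; the single step shown is unreadable, and compound 1 differs from compound 4 in more than one place. The expectation for compound 4 thus rests on compound 2 alone, with no reason drawn from the data to expect a step of readable size in either direction, a number no higher from compound 2 to compound 4 (the limit leaves the size open). Compound 4 is estimated at 150000 nM, in the range 40000 nM to 400000 nM, most likely reported again as a limit in this assay.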

Compound 4, half-maximal inhibitory concentration: > 150000 nM
Compound 4: a limit, no number; the forecaster's own chance of this, stated with the estimate: 70%; the middle value lies on the limit itself.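

In this assay compound 4 gives > 150000 nM, a limit and not a number, so no step from compound 2 to compound 4 can be read, as both stand at the same limit: the limit of > 150000 nM in this assay, at which 3 of the 4 values shown sit.

The compounds shown leave open what 4-nitrophenyl to 4-fluorophenyl does to inhibition in this assay, where only compound 1 has a number.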